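Hydroxy to Methoxy: What Compound 4 Might Tolerate

A few compounds are considered here, and "the series" means these few. Any claim that something is new, unique, unknown or untested is made for them only; others in the source may bear on it.

Of the compounds shown here, three have so far been tested in an ADME assay on RAW264.7 cells (Mus musculus) for cytotoxicity, read by MTT assay, with a stated time of 24 h; a higher number here means that more compound is tolerated, a lower number that less compound is tolerated. Compound 1 `COc1ccccc1C(=O)Nc1ccc(Cl)cc1F` gives no number here but only a limit of the assay, > 40000 nM. Compound 2 `O=C(Nc1ccc(F)cc1F)c1ccccc1` likewise stops at a limit, > 40000 nM. Compound 3 `O=C(Nc1ccc(I)cc1F)c1ccccc1O` is the only one of the three to yield an actual number, 23300 nM. The other two sit at the limit (the limit of > 40000 nM in this assay, at which 2 of the 3 values shown sit).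

Compound 4 `COc1ccccc1C(=O)Nc1ccc(I)cc1F` has not yet been measured. It differs from compound 3 by methyl in place of hydrogen on an oxygen on an aromatic ring, which read one bond further out is hydroxy to methoxy. Within the data shown here, no two measured compounds differ in a single place, so no measured step tells what this change does in this assay. Compound 1 carries the same methoxy group and sits at the limit, while compound 3 carries the hydroxy and gives a number.

Compound 4 is expected to move toward that limit, an estimated step of a 1.7-fold higher number from compound 3 to compound 4 (0.23 log units; within the scatter) in this assay. The expected value for compound 4 is 40000 nM, with a range from 20000 nM to 80000 nM, and a fair chance that the assay again reports only a limit.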

Compound 4, half-maximal cytotoxic concentration: > 40000 nM
Compound 4 gave a limit, no number; the forecaster's own chance of this, stated with the estimate: 55%; the middle value lies on the limit itself.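

On this oxygen, methyl in place of hydrogen now has its first measured step in this assay: an at least 1.7-fold higher number from compound 3 to compound 4 (0.23 log units; that floor lies within the scatter). Only the lower edge of that step is known, so the pair leaves the true size unsettled and does not by itself establish a real change. Compound 1 and compound 4, which differ by iodo in place of chloro, give a step that cannot be read, as both rest on the same limit: the limit of > 40000 nM in this assay, at which 3 of the 4 values shown sit.

On these data alone, the true tolerated concentration of compound 4 remains unknown, so the full effect of replacing hydroxy with methoxy stays open. Also open, as far as these compounds go, is how this assay would respond to an ethyl group, a longer chain on this oxygen, or to a carboxylic acid in place of the hydroxy.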